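Cytotoxicity notes: diethylamino for dimethylamino on the shared core

The source may report more compounds than this note shows. Statements on the series, on what has been measured and on what is new or still open speak of the compounds shown alone.

Measured in an ADME assay on cells (Homo sapiens) for cytotoxicity, read by sulforhodamine B assay, with a stated time of 48 h; on this read-out lower numbers stand for an effect already at smaller amounts and higher numbers for an effect only at larger amounts of compound:
- compound 1 `CCN(CC)c1ccc(/C=C2/SC(Nc3ccccc3)=NC2=O)cc1`: compound 1 gives > 100000 nM, a limit of this assay and not a number.
- compound 2 `CCN(CC)c1ccc(/C=C2/SC(N(c3ccccc3)c3ccccc3)=NC2=O)cc1`: compound 2 gives > 100000 nM, again a limit and not a number.
- compound 3 `CN(C)c1ccc(/C=C2/SC(N(C)c3ccccc3)=NC2=O)cc1`: compound 3 gives > 100000 nM, also a limit and not a number.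

Compound 3 therefore stands only at the limit, as described by the limit of > 100000 nM in this assay, at which 3 of the 3 values shown sit, and no ranking among the three measured compounds can be read from this assay.

Compound 4 `CCN(CC)c1ccc(/C=C2/SC(N(C)c3ccccc3)=NC2=O)cc1` differs from compound 3 in one place: diethylamino in place of dimethylamino on an aromatic carbon. For the measured compounds named here, the sole measured step on the shared core is a step that the two limits leave unreadable from compound 1 to compound 2, which concerns a change at the nitrogen outside the ring rather than the amino group on the ring, and its size cannot be read because both ends sit at the limit. No measured pair isolates the change from dimethylamino to diethylamino, so no size or direction of step can be drawn from the shown data.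

Given that every shown value in this assay is a limit, compound 4 is expected to sit at the limit as well, estimated near 150000 nM with a range from 50000 nM to 500000 nM. The step from compound 3 to compound 4 is accordingly expected to be a step that the limit leaves unreadable from compound 3 to compound 4, within the scatter.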

Compound 4, half-maximal effective concentration: > 100000 nM
Compound 4 gave a limit, no number; the forecaster's own chance of this, stated with the estimate: 85%; the middle value is on the limit's open side.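

In this assay, for the compounds shown here, no step to compound 4 from compound 1, compound 2 or compound 3 can be read, and every value is a limit and not a number: the limit of > 100000 nM in this assay, at which 4 of the 4 values shown sit.

The compounds shown leave open whether any change on the shared core, including diethylamino in place of dimethylamino, shifts cytotoxicity, and by how much.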